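The compounds below may be only part of what the source reports. "The series", "measured", "known", "first", "only" and "open" are said of these compounds alone.

Series notes, cytotoxicity set. For the measured compounds named here, the shared core carries a thiophene on the carbon with a double bond to nitrogen, and that group is the only place where the members differ. Compound 1 `Cc1cc(C2=NNC(c3ccc(N4CCCCC4)cc3)C2)c(C)s1` bears 2,5-dimethylthiophen-3-yl there; in an ADME assay on PBMC cells (Homo sapiens) for cytotoxicity, with a stated time of 5 days (a lower number here means a stronger inhibitor, a higher number a weaker inhibitor), compound 1 gives 77500 nM. Compound 2 `Clc1ccc(C2=NNC(c3ccc(N4CCCCC4)cc3)C2)s1` bears 5-chlorothiophen-2-yl instead. In this assay compound 2 returns a limit of the assay, > 100000 nM, so only a range is known for it. The step of an at least 1.2-fold higher number from compound 1 to compound 2 (0.11 log units; that floor lies within the scatter) is accordingly a floor rather than a number; as the limit of > 100000 nM in this assay, at which 1 of the 2 values shown sits, records, one of the two values shown sits at that limit.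

Compound 3 `Clc1cc(C2=NNC(c3ccc(N4CCCCC4)cc3)C2)c(Cl)s1` is the next member: 2,5-dichlorothiophen-3-yl in place of 5-chlorothiophen-2-yl on a carbon with a double bond to nitrogen. Going by the values given here, the only measured step that touches this position is an at least 1.2-fold higher number from compound 1 to compound 2 (0.11 log units; that floor lies within the scatter), a swap of one thiophene for another, and it did not move the number beyond the scatter. Among the compounds with values here, no step separates a dichlorinated thiophene from the chlorinated or dimethylated ones. For compound 3 the expected step is a number no higher from compound 2 to compound 3 (the limit leaves the size open), nothing beyond the scatter. Compound 3 is therefore estimated at 100000 nM, with a range from 40000 nM to 250000 nM, and with a real chance that compound 3 again returns only the limit of this assay.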

Compound 3, half-maximal inhibitory concentration: 59000 nM
Estimate against measurement, compound 3: 1.7-fold (0.23 log units) above; measured number inside the range.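

The swap to 2,5-dichlorothiophen-3-yl from 5-chlorothiophen-2-yl gives, in this assay, an at least 1.6-fold lower number from compound 2 to compound 3 (0.22 log units; that floor lies within the scatter), so this change shows no shift beyond the scatter, though the step has only a lower bound on its size. For the compounds shown here, the comparison of 2,5-dichlorothiophen-3-yl with 2,5-dimethylthiophen-3-yl gives a 1.3-fold lower number from compound 1 to compound 3 (0.12 log units; within the scatter); this is the first step at this position with a number at both ends, and it does not tell the dichlorinated and dimethylated thiophenes apart. Compound 2 remains the one member at a limit of the assay, so its steps stay floors: the limit of > 100000 nM in this assay, at which 1 of the 3 values shown sits.

Whether any group at this position can move the number beyond the scatter stays open, since the compounds shown hold only thiophenes there, carrying chlorine or methyl, and they give no reading for a phenyl ring, a primary amine or a carboxylic acid in that place. With this assay as the only read-out shown, it also stays open how these thiophene changes would read in any other assay.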